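This account rests on a few compounds, and the source may have more. Where it says the series, first, only, none or still open, it means among the compounds named here.

Measured compounds:
Compound 1 `CC(C)(C)N(NC(=O)c1cccc(F)c1)C(=O)c1ccccc1Cl` gives 69.2 nM in an assay on cells for agonist activity at ecdysone receptor (Bombyx mori), read by a luciferase reporter, with a stated time of 24 h; on this read-out higher numbers stand for an effect only at larger amounts of compound and lower numbers for an effect already at smaller amounts.
Compound 2 `COc1ccc(C(=O)NN(C(=O)c2ccccc2Cl)C(C)(C)C)cc1` gives 51.3 nM in this assay.

Within the data shown here, compound 2 holds the lowest of the two numbers so far, but its nearest neighbour is compound 1, and the step of a 1.3-fold lower number from compound 1 to compound 2 (0.13 log units; within the scatter) falls within the scatter, so the two values cannot be ordered. Compound 3 `Cc1ccc(C(=O)NN(C(=O)c2ccccc2Cl)C(C)(C)C)cc1C` has not yet been measured in this assay. It differs from compound 2 in one place: 3,4-dimethylphenyl in place of 4-methoxyphenyl on a carbonyl carbon. Among the measured compounds shown here, the only measured step that bears on this change is the one on the same carbonyl carbon, a 1.3-fold lower number from compound 1 to compound 2 (0.13 log units; within the scatter), which was small. On that basis no step beyond the scatter is expected from compound 2 to compound 3 in this assay, and the estimated step is a 1.1-fold lower number from compound 2 to compound 3 (0.06 log units; within the scatter). Compound 3 is therefore expected to give about 45 nM, with a range from 18 nM to 120 nM.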

Compound 3, half-maximal effective concentration: 87.1 nM
Compound 3: middle estimate off by 1.9-fold (0.29 log units), on the low side; the range from low to high includes it.
By their numbers in this assay, from the lowest: compounds 2, 1 and 3 (each within the scatter of the next).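

At the carbonyl carbon, the series now holds a third substituted phenyl group: moving to 3,4-dimethylphenyl gives a 1.7-fold higher number from compound 2 to compound 3 (0.23 log units; within the scatter) in this assay and a 1.3-fold higher number from compound 1 to compound 3 (0.10 log units; within the scatter) when it takes the place of 3-fluorophenyl. The entering group has no oxygen and no hydrogen-bond acceptor where 4-methoxyphenyl has one, yet this exchange stays within the scatter, so the three groups at this place cannot be told apart in this assay. Nothing available gives a reason for the values seen here. The compounds shown leave open whether a group other than a substituted phenyl, such as a pyridine ring, an amine, a carboxylic acid or a longer alkyl chain, would move the number beyond the scatter. They also leave open how changes elsewhere on the shared core would read out.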